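Ester in place of methyl on the oxime-ether aryl ring

This account rests on a few compounds, and the source may have more. Where it says the series, first, only, none or still open, it means among the compounds named here.

Measured compounds:
Compound 1 `COc1ccc(CO/N=C/c2c(C)nn(C)c2Oc2ccc(Cl)cc2)cc1`, 43.9%
Compound 2 `Cc1ccc(CO/N=C/c2c(C)nn(C)c2Oc2ccc(Cl)cc2)cc1`, 50%

Among the compounds with values here, compound 2 has the higher of the two numbers in a functional assay on A549 cells (Homo sapiens) for antiproliferative activity, tested at 1 uM (on this read-out lower numbers stand for less inhibition and higher numbers for more inhibition at the one concentration tested (going by the name of the read-out)), yet the one step of a number 6.1 percentage points higher from compound 1 to compound 2 (within the scatter) lies within the scatter, so the two compounds cannot be ranked. Compound 3 `CCOC(=O)c1ccc(CO/N=C/c2c(C)nn(C)c2Oc2ccc(Cl)cc2)cc1` carries ethoxycarbonyl in place of methyl on an aromatic carbon. Within the data shown here, no measured step exchanges a methyl for a group of this kind, so nothing here bears directly on it; the only step, from methoxy to methyl, was small. With no guidance from the data, the change to compound 3 is expected to be a number 3 percentage points lower from compound 2 to compound 3 (within the scatter), no step beyond the scatter. Compound 3 is therefore estimated at 47%, between 28% and 66%.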

Compound 3, a percentage reported as inhibition, at one concentration (the size of the read-out at that concentration, not a potency): 48.2%
For compound 3 the middle estimate is 1.2 percentage points below the measured one, within the range that was stated.
By their numbers in this assay, from the lowest: compounds 1, 3 and 2 (each within the scatter of the next).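

Ethoxycarbonyl brings 5 heavy atoms and 2 hydrogen-bond acceptors to this aromatic carbon, where methyl has 1 heavy atom and no acceptors, yet this assay shows a number 1.8 percentage points lower from compound 2 to compound 3 (within the scatter) and, for the exchange with methoxy, a number 4.3 percentage points higher from compound 1 to compound 3 (within the scatter). At this place, para to a large group, methyl, methoxy and ethoxycarbonyl therefore cannot be told apart in this read-out. Nothing available explains this result. Going by these compounds, a carboxylic acid or an amine at the same carbon remains open, as does a longer ester chain.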